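Sulfanyl to sulfonyl on the enone chain of compound 1

A few compounds are considered here, and "the series" means these few. Any claim that something is new, unique, unknown or untested is made for them only; others in the source may bear on it.

Measured so far in a functional assay on DU-145 cells (Homo sapiens) for inhibition, read by trypan blue exclusion, with a stated time of 96 h; a lower number here means a stronger inhibitor of growth, a higher number a weaker inhibitor of growth:
Compound 1 `Cc1ccc(S/C(=C/c2c[nH]c3ccccc23)C(=O)c2ccc(Br)cc2)cc1` gives 10000 nM in this assay.
Compound 2 `CSc1ccc(/C=C(/Sc2ccc(C)cc2)C(=O)c2ccc(Br)cc2)cc1` gives 50000 nM in this assay.
Compound 3 `Cc1ccc(S/C(=C/c2c[nH]c3ccc(Br)cc23)C(=O)c2ccc(Br)cc2)cc1` gives 1000 nM in this assay.

Compound 1 stands second highest of the three numbers. Its nearest neighbour is compound 2, a 5.0-fold higher number from compound 1 to compound 2 (0.70 log units; beyond the scatter), and the furthest is compound 3, a 10-fold lower number from compound 1 to compound 3 (1.00 log units; beyond the scatter). Both steps alter parts of compound 1 away from the sulfur-bearing chain carbon: the first swaps the aromatic unit on the double-bonded chain carbon, the second adds a bromo to that aromatic unit.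

Compound 4 `Cc1ccc(S(=O)(=O)/C(=C/c2c[nH]c3ccccc23)C(=O)c2ccc(Br)cc2)cc1` differs from compound 1 in a different place: (4-methylphenyl)sulfonyl in place of (4-methylphenyl)sulfanyl on a double-bonded chain carbon bound to a carbonyl carbon and a double-bonded chain carbon. For the measured compounds named here, neither measured step touches this position, so no step bears directly on the change from sulfanyl to sulfonyl. The two measured steps show that this assay does register modest moves when the core of compound 1 is altered, but they give no direction for the present change. The expectation for compound 4 in this assay is therefore a number close to that of compound 1, with the step of no change at the digits printed from compound 1 to compound 4 (within the scatter) estimated as not beyond the scatter, and a wide range to cover either direction. The estimate for compound 4 is 10000 nM, between 3000 nM and 40000 nM.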

Compound 4, concentration for 50% growth inhibition: 10000 nM
For compound 4 middle estimate and measured number coincide at the digits printed; the range from low to high includes it.
By their numbers in this assay, from the lowest: compound 3; then compounds 1 and 4 (each within the scatter of the next); then compound 2.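

The position on the double-bonded chain carbon bound to a carbonyl carbon and a double-bonded chain carbon now has its first direct reading: in this assay, (4-methylphenyl)sulfonyl in place of (4-methylphenyl)sulfanyl gives no change at the digits printed from compound 1 to compound 4 (within the scatter). The earlier steps shown here changed only the aromatic unit on the other chain carbon and moved the number beyond the scatter, whereas two added oxygens on this sulfur leave it within the scatter. Nothing shown explains this flat result, which stands here as a measured growth-inhibition number with no supporting data on the change itself.

Open, going by these compounds, is whether the same change stays flat when the bromo of compound 3 is present, compound 3 giving 1000 nM, or when the 4-(methylsulfanyl)phenyl of compound 2 replaces the 1H-indol-3-yl. Also open, on these data alone, is how this position responds to a sulfinyl link, a methylene link or an amide link in place of the sulfur, any of which would show whether the flat result extends beyond this one pair.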